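Two Flat Results and a Sulfonyl Swap on the Shared Core

The compounds below may be only part of what the source reports. "The series", "measured", "known", "first", "only" and "open" are said of these compounds alone.

Compound 1 `O=c1c(S(=O)(=O)c2ccc(F)cc2F)cc2cnc(Nc3ccc4[nH]ccc4c3)nc2n1C1CCCC1`: 5000 nM
Compound 2 `Cn1c(=O)c(C(=O)Nc2ccc(F)cc2)cc2cnc(Nc3ccc4[nH]ccc4c3)nc21`: 5000 nM

In a functional assay on DU-145 cells (Homo sapiens) for inhibition, read by trypan blue exclusion, with a stated time of 72 h (a higher number here means a weaker inhibitor, a lower number a stronger inhibitor), compound 1 gives 5000 nM. In this assay compound 2 gives 5000 nM, level with compound 1 and within the scatter of it. Compound 3 `Cn1c(=O)c(S(=O)(=O)c2ccc(N)cc2F)cc2cnc(Nc3ccc4[nH]ccc4c3)nc21` has not yet been measured. It differs from compound 2 by (4-amino-2-fluorophenyl)sulfonyl in place of (4-fluorophenyl)carbamoyl on an aromatic carbon. Within the data shown here, no measured pair shows what this kind of change does on the shared core, so the step from compound 2 to compound 3 is expected to be small, perhaps a modest gain, as a 1.7-fold lower number from compound 2 to compound 3 (0.22 log units; within the scatter). Compound 3 is therefore estimated at 3000 nM, within 800 nM to 10000 nM.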

Compound 3, half-maximal inhibitory concentration: 8000 nM
Compound 3: the middle estimate sits 2.7-fold (0.43 log units) below what was measured; measured number inside the range.
By their numbers in this assay, from the lowest: compounds 1, 2 and 3 (each within the scatter of the next).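

Putting (4-amino-2-fluorophenyl)sulfonyl in place of (4-fluorophenyl)carbamoyl on this aromatic carbon gives, in this assay, a 1.6-fold higher number from compound 2 to compound 3 (0.20 log units; within the scatter). This is the first pair shown to differ in one place, and it shows that this exchange of the carbamoyl link and its aryl group for the sulfonyl link and its aryl group stays within the scatter on the shared core. No measurement offered here explains this result. The compounds shown leave open whether the amine on the aryl ring matters by itself, and whether a carboxylic acid or a nitrile on this aromatic carbon would move the number beyond the scatter.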